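The compounds below may be only part of what the source reports. "The series", "measured", "known", "first", "only" and "open" are said of these compounds alone.

Of the compounds shown here, three sharing one core have been tested in an assay on HL-60 cells for agonist activity at N-formyl peptide receptor 3 (Homo sapiens), read by calcium flux; on this read-out lower numbers stand for an effect already at smaller amounts and higher numbers for an effect only at larger amounts of compound. Compound 1 `Cc1cc(Cc2cccc(Cl)c2)c(=O)n(CC(=O)Nc2ccc(Br)cc2)n1` carries a 3-chlorophenyl group on a saturated chain carbon bound to an aromatic carbon; in this assay compound 1 reaches only > 50000 nM, which is a limit of the assay rather than a number. Compound 2 `Cc1cc(Cc2cccs2)c(=O)n(CC(=O)Nc2ccc(Br)cc2)n1` carries thiophen-2-yl in that place, and in this assay compound 2 gives 10200 nM. Compound 3 `Cc1cc(Cc2cccnc2)c(=O)n(CC(=O)Nc2ccc(Br)cc2)n1` carries pyridin-3-yl there; in this assay compound 3 also stops at > 50000 nM, again a limit and not a number. Compound 2 stands apart: there is an at least 4.9-fold lower number from compound 1 to compound 2 (0.69 log units; beyond the scatter) and an at least 4.9-fold higher number from compound 2 to compound 3 (0.69 log units; beyond the scatter), whereas a step that the two limits leave unreadable from compound 1 to compound 3 is not readable because of the limit of > 50000 nM in this assay, at which 2 of the 3 values shown sit.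

Compound 4 `COc1ccc(-c2cc(C)nn(CC(=O)Nc3ccc(Br)cc3)c2=O)cc1` differs from compound 3 by 4-methoxyphenyl in place of (pyridin-3-yl)methyl on an aromatic carbon. Among the measured compounds shown here, none of the measured steps bears on this change: each of them swapped the ring on the saturated chain carbon, whereas here that carbon is removed and a ring is attached directly. Since compound 3 sits at a limit, no step size can be read from it either. With the set as a whole weak, compound 4 is estimated at 30000 nM, somewhere within 5000 nM to 60000 nM. The step this expectation implies is an at least 1.6-fold lower number from compound 3 to compound 4 (0.22 log units; that floor lies within the scatter).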

Compound 4, half-maximal effective concentration: > 50000 nM
Compound 4: only a limit was reported; the forecaster's own chance of this, stated with the estimate: 55%; middle value at least 1.6-fold (0.22 log units) away from the limit.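

The first ring set directly on this aromatic carbon, 4-methoxyphenyl without the saturated chain carbon, brings no gain over the thiophen-2-yl group on that carbon: there is an at least 4.9-fold higher number from compound 2 to compound 4 (0.69 log units; beyond the scatter). Compound 2 therefore remains the only one of the four with a readable number in this assay. The steps that link compound 4 to compound 1 and to compound 3 cannot be read, because both ends of each step sit at the same assay limit: the limit of > 50000 nM in this assay, at which 3 of the 4 values shown sit.

Compound 4 differs from compound 2 in both the ring and the chain carbon, so this single step does not show which of the two changes counts. Still open, from the compounds shown here alone, is what thiophen-2-yl would give directly on the aromatic carbon, and what a longer chain carrying that ring, or an amine at this position, would give.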